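The compounds below may be only part of what the source reports. "The series", "measured", "known", "first", "only" and "open" are said of these compounds alone.

Working notes on the series in a functional assay on KB 3-1 cells (Homo sapiens) for cytotoxicity, read by MTT assay, with a stated time of 68 h; on this read-out higher numbers stand for weaker inhibition and lower numbers for stronger inhibition. Compound 1 `CSc1cccc(-c2cc(NC(=O)C(Cl)Cl)cc(-c3cccc(SC)c3)c2)c1` returns only a limit of the assay, (the limit of > 30000 nM in this assay, at which 1 of the 3 values shown sits), so its entry stands as > 30000 nM. Compound 3 `O=C(Nc1cccc(-c2ccccc2Cl)c1)C(Cl)Cl` likewise returns a limit, (the limit of > 50000 nM in this assay, at which 1 of the 3 values shown sits), recorded as > 50000 nM. Going by the values given here, compound 2 `Nc1cccc(-c2cccc(NC(=O)C(Cl)Cl)c2)c1` is the one member with a measured number: in this assay compound 2 gives 26100 nM. Among the compounds with values here, compound 2 therefore holds the sole numerical value in the set, and the two remaining entries, being limits, cannot be ordered against it.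

Compound 4 `Cc1cccc(-c2cccc(NC(=O)C(Cl)Cl)c2)c1` has not yet been run in this assay. It differs from compound 2 in one place: methyl in place of amino on an aromatic carbon. Within the data shown here, no measured pair in the set covers this exchange, so no step of known size is available to anchor a prediction. With compound 2 at 26100 nM, the exchange is expected to move the number little, in no direction beyond the usual scatter. A sizeable chance remains that compound 4 comes back as a limit rather than a number. The expected step is a 1.1-fold higher number from compound 2 to compound 4 (0.06 log units; within the scatter). Compound 4 is estimated at 30000 nM in this assay, with a range from 10000 nM to 90000 nM.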

Compound 4, half-maximal inhibitory concentration: > 50000 nM
Compound 4 gave a limit, no number; the forecaster's own chance of this, stated with the estimate: 40%; middle value at least 1.6-fold (0.22 log units) away from the limit.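

Going by these compounds alone, this is the first pair that differs in one place, so the amino group on this aromatic carbon can now be read against a neighbouring group for the first time. In this assay, going by these compounds, methyl in place of amino gives an at least 1.9-fold higher number from compound 2 to compound 4 (0.28 log units; that floor lies within the scatter), and this figure is only a floor on the step, so the true size stays unknown and the data do not establish a real loss of potency. Compound 4 returns a limit and not a number, which leaves compound 2 as the only member of the series with a measured value, and compound 4 joins the entries at the upper limit: the limit of > 50000 nM in this assay, at which 2 of the 4 values shown sit.

The compounds shown leave open how far the true value of compound 4 lies beyond its limit, and so whether the amino group contributes anything measurable to the number for compound 2. They also leave open whether a hydroxyl, a methoxy, a dimethylamino or a carboxylic acid on this same aromatic carbon would return a measured number, as compound 2 does, or a limit, as compound 4 does.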